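The source may report more compounds than this note shows. Statements on the series, on what has been measured and on what is new or still open speak of the compounds shown alone.

In a functional assay on DU-145 cells (Homo sapiens) for inhibition, read by CCK-8 assay, with a stated time of 72 h (a higher number here means a weaker inhibitor, a lower number a stronger inhibitor), two compounds sharing one core have been measured so far. Compound 1 `Cc1ccccc1NS(=O)(=O)c1cccc(CCCCCCNC(=O)/C=C/c2cccnc2)c1` gives 2.9 nM and compound 2 `CC(C)(C)c1ccc(NS(=O)(=O)c2cccc(CCCCCCNC(=O)/C=C/c3cccnc3)c2)cc1` gives 281 nM as the higher of the two numbers, which makes compound 2 the weaker inhibitor of the pair. Within the data shown here, the only measured step (a 97-fold higher number from compound 1 to compound 2 (1.99 log units; beyond the scatter)) is large, and it came with 4-(tert-butyl)phenyl in place of 2-methylphenyl on a sulfonamide nitrogen. Compound 3 `O=C(/C=C/c1cccnc1)NCCCCCCc1cccc(S(=O)(=O)Nc2ccc(F)cc2)c1` differs from compound 2 in one place (fluoro in place of tert-butyl on an aromatic carbon): fluoro in place of tert-butyl on an aromatic carbon, para to a large group. The measured step bears on this change only in part, as it replaced a whole substituted phenyl and does not show how much of the gap belongs to the tert-butyl group alone. Losing that group is still expected to recover part of the distance from compound 2 (281 nM) towards compound 1 (2.9 nM), though probably not all of it. The step expected in this assay is therefore towards a lower number, sizeable but smaller than the measured one (estimated as a 9.4-fold lower number from compound 2 to compound 3 (0.97 log units; beyond the scatter)). For compound 3 the estimated value is 30 nM (expected range 6 nM to 150 nM).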

Compound 3, half-maximal inhibitory concentration: 10.6 nM
The estimate for compound 3 lay 2.8-fold (0.45 log units) above the measured number; low and high end bracket the measured number.
By their numbers in this assay, from the lowest: compound 1; then compound 3; then compound 2.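

In this assay, changing one group on an aromatic carbon, para to a large group, gives a 27-fold lower number from compound 2 to compound 3 (1.42 log units; beyond the scatter). The earlier step swapped a whole substituted phenyl, whereas this one leaves everything else in compound 2 untouched, so it shows that replacing tert-butyl with fluoro at this one place is enough for a large change in the number. A smaller gap remains on the other side, with a 3.7-fold higher number from compound 1 to compound 3 (0.56 log units; beyond the scatter); this step is modest but still beyond the scatter, so compound 1 stays the strongest inhibitor of the three.

That last step changes both the group and its place on the phenyl ring, so the compounds shown cannot separate the two, and a methyl, chloro or methoxy group in place of the fluoro would test how much depends on the group itself. They also leave open why tert-butyl goes with the weaker inhibition, as no supporting measurement is available to explain any of these differences.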